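The compounds below may be only part of what the source reports. "The series", "measured", "known", "first", "only" and "open" are said of these compounds alone.

In a functional assay on MCF7 cells (Homo sapiens) for cytotoxicity, read by fluorescence, with a stated time of 72 h (on this read-out higher numbers stand for weaker inhibition and lower numbers for stronger inhibition), compound 1 `CC(C)c1n[nH]c2c(NCc3ccc(-c4ccccn4)cc3)nc(NCC(C)(C)O)nc12` gives 24 nM, compound 2 `CC(C)c1n[nH]c2c(NCc3ccc(-c4ccccn4)cc3)nc(N3CCCCC3CCO)nc12` gives 133 nM, and compound 3 `CC(C)c1n[nH]c2c(NCc3ccc(-c4ccccn4)cc3)nc(NCC(N)CO)nc12` gives 310 nM, the highest of the three numbers. Compound 4 `CC(C)c1n[nH]c2c(NCc3ccc(-c4ccccn4)cc3)nc(NCc3ccc(-c4ccccn4)cc3)nc12` carries 4-(pyridin-2-yl)phenyl in place of the 1-amino-2-hydroxyethyl of compound 3, on a saturated chain carbon bound to a nitrogen on an aromatic ring: 4-(pyridin-2-yl)phenyl in place of 1-amino-2-hydroxyethyl on a saturated chain carbon bound to a nitrogen on an aromatic ring.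

The closest evidence is a change at this same place, a 13-fold higher number from compound 1 to compound 3 (1.11 log units; beyond the scatter), which was large. Two wider changes at the same substituent were modest: a 5.5-fold higher number from compound 1 to compound 2 (0.74 log units; beyond the scatter) and a 2.3-fold higher number from compound 2 to compound 3 (0.37 log units; beyond the scatter). Going by the values given here, these steps show that the number responds to changes in this substituent, but none of the measured compounds has an aromatic group there, so they do not fix a direction for the new change. With compound 3 already at the top of the measured numbers, no step beyond the scatter is expected, with only a slight lean towards a lower number. The expected change is a 1.2-fold lower number from compound 3 to compound 4 (0.09 log units; within the scatter). For compound 4 the estimated value is 250 nM, with an expected range of 50 nM to 1200 nM.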

Compound 4, half-maximal inhibitory concentration: 2390 nM
Compound 4: middle estimate off by 9.6-fold (0.98 log units), on the low side; the whole stated range lies below it.
By their numbers in this assay, from the lowest: compound 1; then compound 2; then compound 3; then compound 4.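

In this assay, going by these compounds alone, the first aromatic group seen on this saturated chain carbon bound to a nitrogen on an aromatic ring does not leave the number near that of the earlier compounds: 4-(pyridin-2-yl)phenyl gives a 7.7-fold higher number from compound 3 to compound 4 (0.89 log units; beyond the scatter) and a 100-fold higher number from compound 1 to compound 4 (2.00 log units; beyond the scatter). Within the data shown here, the earlier steps showed only that the number responds to changes among non-aromatic groups here, whereas this change shows that 1-hydroxy-1-methylethyl and 1-amino-2-hydroxyethyl both give lower numbers than this two-ring group. Nothing given here accounts for the rise.

The compounds shown leave open whether the rise belongs to the phenyl ring, the pyridine ring or the two together, which a plain phenyl at this place would begin to separate. From the compounds shown here alone, how a carboxylic acid or a longer chain ending in a hydroxyl would read here also remains open.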